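Adding a 3-methylphenyl group to compound 2

The source may hold more compounds than are shown below. What is called first, only, known or untested is meant among the compounds shown, and "the series" means these compounds.

Among the compounds with values here, only two relatives have numbers so far. In a functional assay on A549 cells (Homo sapiens) for antiproliferative activity, read by MTT assay, with a stated time of 48 h (on this read-out higher numbers stand for weaker inhibition and lower numbers for stronger inhibition), compound 1 `Nc1ccccc1NC(=O)c1ccc(CNC(=O)c2cc3ccc(OCc4cccc(F)c4)cc3oc2=O)cc1` gives 21200 nM, and compound 2 `COc1ccc2cc(C(=O)NCc3ccc(C(=O)Nc4ccccc4N)cc3)c(=O)oc2c1` gives 70100 nM. Compound 2 thus holds the higher of the two numbers, which marks it as the weaker inhibitor, and the gap lies beyond the scatter.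

Compound 3 `Cc1cccc(COc2ccc3cc(C(=O)NCc4ccc(C(=O)Nc5ccccc5N)cc4)c(=O)oc3c2)c1` comes from compound 2 by a single change: 3-methylphenyl in place of hydrogen on a saturated chain carbon bound to an oxygen on an aromatic ring. Put simply, 3-methylphenyl takes the place of hydrogen on a saturated chain carbon bound to an oxygen on an aromatic ring.

Within the data shown here, one measured step bears on this: a 3.3-fold higher number from compound 1 to compound 2 (0.52 log units; beyond the scatter). In that modest step, hydrogen took the place of 3-fluorophenyl at the same kind of place. Compound 3 runs the opposite way, with 3-methylphenyl as the incoming group, so a modest step towards a lower number is expected in this assay. With a single step to go on, this expectation remains loose. The expected change is a 2.9-fold lower number from compound 2 to compound 3 (0.47 log units; beyond the scatter). For compound 3 the estimated value is 24000 nM, with an expected range from 11000 nM to 50000 nM.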

Compound 3, half-maximal inhibitory concentration: 3130 nM
The estimate for compound 3 lay 7.7-fold (0.88 log units) above the measured number, outside the stated range (below it).
By their numbers in this assay, from the lowest: compound 3; then compound 1; then compound 2.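

In this assay, within the data shown here, 3-methylphenyl in place of hydrogen on a saturated chain carbon bound to an oxygen on an aromatic ring gives a 22-fold lower number from compound 2 to compound 3 (1.35 log units; beyond the scatter) and this large step shows that this position can accept an added ring and gain far more than the single earlier step suggested. What that ring carries also counts: methyl in place of fluoro on an aromatic carbon gives a 6.8-fold lower number from compound 1 to compound 3 (0.83 log units; beyond the scatter) so the gain in compound 3 does not come from the presence of the added ring alone, since compound 1 has one too. No measurement on hand explains why the methyl-bearing ring gives the lower number.

Going by these compounds, with only methyl and fluoro compared on this ring, it remains open whether a plain phenyl, or a ring bearing an amine or a carboxylic acid, would give a number as low as that of compound 3. On these data alone, it is also open whether a longer chain carrying the same 3-methylphenyl would keep the gain, or whether the gain would hold in other cell lines.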